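This account rests on a few compounds, and the source may have more. Where it says the series, first, only, none or still open, it means among the compounds named here.

Three members of the series have been run in a functional assay on isolated protein for inhibition of Glucose-dependent insulinotropic receptor (Homo sapiens), read by HTRF and cAMP accumulation; a lower number here means that less compound is needed, a higher number that more compound is needed for the effect. Compound 1 `Cc1nc(S(C)(=O)=O)ccc1Oc1ncnc(OC2CCN(C(=O)OC(C)(C)CF)CC2)c1F` gives 19.9 nM, compound 2 `Cc1nc(S(C)(=O)=O)ccc1Oc1ncnc(OC2CCN(C(=O)O[C@@H](C)CF)CC2)c1F` gives 186 nM and compound 3 `Cc1nc(S(C)(=O)=O)ccc1Oc1ncnc(OC2CCN(C(=O)SC3CCC3)CC2)c1F` gives 8.51 nM; compound 3 stands lowest of the three, with compound 1 nearest and compound 2 furthest. Compound 4 `CCC(F)(F)C(=O)N1CCC(Oc2ncnc(Oc3ccc(S(C)(=O)=O)nc3C)c2F)CC1` is not yet measured; it differs from compound 3 by 1,1-difluoropropyl in place of cyclobutylsulfanyl on a carbonyl carbon. Among the compounds with values here, two measured steps bear on this change, both at the same carbonyl carbon: a 2.3-fold lower number from compound 1 to compound 3 (0.37 log units; beyond the scatter) and a 22-fold lower number from compound 2 to compound 3 (1.34 log units; beyond the scatter). Both run toward compound 3, so leaving the cyclobutylsulfanyl group is expected to raise the number by a modest step. For compound 4 the expected step is a 3.5-fold higher number from compound 3 to compound 4 (0.55 log units; beyond the scatter). Compound 4 is therefore estimated at 30 nM, with a range of 10 nM to 100 nM.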

Compound 4, half-maximal effective concentration: 17.4 nM
Estimate against measurement, compound 4: 1.7-fold (0.24 log units) above; the measured number falls inside the stated range.
By their numbers in this assay, from the lowest: compound 3; then compounds 4 and 1 (each within the scatter of the next); then compound 2.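

Replacing cyclobutylsulfanyl with 1,1-difluoropropyl on a carbonyl carbon gives a 2.0-fold higher number from compound 3 to compound 4 (0.31 log units; beyond the scatter) and shows that neither the sulfur nor the four-membered ring is required for a number in this low range. Set against the two oxygen-linked groups, 1,1-difluoropropyl gives an 11-fold lower number from compound 2 to compound 4 (1.03 log units; beyond the scatter) and a 1.1-fold lower number from compound 1 to compound 4 (0.06 log units; within the scatter) and shows that an oxygen on the carbonyl carbon is not required either. No measurement on hand accounts for these steps.

From the compounds shown here alone, whether an amine or a plain propyl chain on the carbonyl carbon holds the number remains open. The role of the two fluorines in 1,1-difluoropropyl also remains unresolved.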